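The source may report more compounds than this note shows. Statements on the series, on what has been measured and on what is new or still open speak of the compounds shown alone.

In a functional assay on P388 cells (Mus musculus) for cytotoxicity (on this read-out higher numbers stand for an effect only at larger amounts of compound and lower numbers for an effect already at smaller amounts), compound 1 `Oc1ccc2nc(-c3ccccc3)cc(O)c2c1` gives 2.86 ug/mL and carries hydroxy on the aromatic carbon followed in these notes. Compound 2 `CC(C)Oc1cc(-c2ccccc2)nc2ccccc12` stands at > 10 ug/mL and this entry is a limit of the assay, not a number. Within the data shown here, compound 3 `Oc1cc(-c2ccccc2)nc2ccc(Cl)cc12` gives 0.84 ug/mL and so holds the lower of the two actual numbers so far, with chloro on that same carbon.

The next structure is compound 4 `COc1ccc2nc(-c3ccccc3)cc(O)c2c1` with methoxy in place of chloro on an aromatic carbon in the shared core. Among the measured compounds shown here, no measured step involves methoxy. For the measured compounds named here, the only step at this carbon is a 3.4-fold lower number from compound 1 to compound 3 (0.53 log units; beyond the scatter) as chloro replaces hydroxy, a modest change that goes beyond the scatter. Going by the values given here, compound 4 gives up the chloro of compound 3, so that step is the only guide, and a weak one, since methoxy is not hydroxy. A step of similar or somewhat smaller size towards a higher number is therefore expected in this assay for this exchange. The expected move is a 2.4-fold higher number from compound 3 to compound 4 (0.38 log units; beyond the scatter) on this reasoning. For compound 4 the estimated value is 2 ug/mL with an expected range from 0.6 ug/mL to 7 ug/mL in this assay once measured.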

Compound 4, half-maximal effective concentration: 0.33 ug/mL
Estimate against measurement, compound 4: 6.1-fold (0.78 log units) above; measured number below the stated range.
By their numbers in this assay, from the lowest: compound 4; then compound 3; then compound 1. At a limit, above all of these: compound 2.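

At the aromatic carbon followed here, chloro no longer gives the lowest number: methoxy in its place gives a 2.5-fold lower number from compound 3 to compound 4 (0.41 log units; beyond the scatter) in this assay and reverses the direction expected from the earlier hydroxy-to-chloro step. Methyl on the oxygen of the hydroxy gives an 8.7-fold lower number from compound 1 to compound 4 (0.94 log units; beyond the scatter) and shows that a free hydroxy on this carbon is not needed for an effect at smaller amounts in this cytotoxicity read-out. Among the three groups compared at this carbon, the order from the lowest number is methoxy, chloro and hydroxy, with each printed step beyond the scatter, but this order rests on compound 1, compound 3 and compound 4 alone.

From the compounds shown here alone, it remains open whether a longer chain such as ethoxy, an amine or a carboxylic acid on this carbon would continue or break this order, and the other hydroxy of the shared core stays unchanged across these three compounds. Nothing measured in these notes bears on what lies behind the lower number of the methoxy compound.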